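Thiadiazolyl for pyrimidinyl on the sulfanyl linker

This account rests on a few compounds, and the source may have more. Where it says the series, first, only, none or still open, it means among the compounds named here.

Measured values in a functional assay on C6 cells (Rattus norvegicus) for cytotoxicity, read by MTT assay, with a stated time of 24 h, tested at 12 ug/mL; a lower number here means a stronger effect, a higher number a weaker effect of the compound at the concentration tested:
compound 1 `Cc1nnc(SCC(=O)N/N=c2/scc(-c3ccc(Cl)cc3)n2-c2ccccc2)s1`: 76.6%
compound 2 `O=C(CSc1ncccn1)N/N=c1/scc(-c2ccc(Cl)cc2)n1-c1ccccc1`: 91.6%
compound 3 `Cc1ccc(-c2cs/c(=N/NC(=O)CSc3ncccn3)n2-c2ccccc2)cc1`: 83%

The series shares one core; compound 2 and compound 3 differ only by methyl in place of chloro on an aromatic carbon, and that change reads as a number 8.6 percentage points lower from compound 2 to compound 3 (within the scatter), so the two values cannot be ordered. For the measured compounds named here, the second change seen is 5-methyl-1,3,4-thiadiazol-2-yl in place of pyrimidin-2-yl on a sulfur, which reads as a number 15 percentage points lower from compound 2 to compound 1 (beyond the scatter), the one step here that stands out from the noise.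

Compound 4 `Cc1ccc(-c2cs/c(=N/NC(=O)CSc3nnc(C)s3)n2-c2ccccc2)cc1` is not yet measured. It carries the same change relative to compound 3, namely (5-methyl-1,3,4-thiadiazol-2-yl in place of pyrimidin-2-yl on a sulfur). The surroundings of the change are the same word for word in both pairs (a sulfur whose other neighbour is a saturated chain carbon), so it is the same change on a core that differs by methyl in place of chloro on an aromatic carbon.

The step from compound 3 to compound 4 is expected to be about a number 15 percentage points lower from compound 3 to compound 4 (beyond the scatter) in this assay, resting on a number 15 percentage points lower from compound 2 to compound 1 (beyond the scatter); with a single earlier occurrence the bounds are kept wide. Compound 4 is thus estimated at 68%, between 55% and 80%.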

Compound 4, a percentage reported as activity, at one concentration (the size of the read-out at that concentration, not a potency): 58.3%
For compound 4 the middle estimate is 9.7 percentage points above the measured one; the measured number falls inside the stated range.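

In this assay the 5-methyl-1,3,4-thiadiazol-2-yl group in place of pyrimidin-2-yl on the sulfur gives a number 24.7 percentage points lower from compound 3 to compound 4 (beyond the scatter), the same direction as on the chloro core, and the two steps do not differ: the same change on two cores in this assay, a number 15 percentage points lower (beyond the scatter) from compound 2 to compound 1 and a number 24.7 percentage points lower (beyond the scatter) from compound 3 to compound 4, 9.7 percentage points apart, within the scatter of two such steps

Methyl in place of chloro on an aromatic carbon now reads as a number 18.3 percentage points lower from compound 1 to compound 4 (beyond the scatter), and this step does not separate from its earlier occurrence either: the same change on two cores in this assay, a number 8.6 percentage points lower (within the scatter) from compound 2 to compound 3 and a number 18.3 percentage points lower (beyond the scatter) from compound 1 to compound 4, 9.7 percentage points apart, within the scatter of two such steps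

On these four compounds the two changes therefore carry from one core to the other without a detectable difference, but a single pair of cores does not establish that this holds on other cores, and a read-out at one concentration gives no potency.

Open, going by these compounds, is whether the step on the sulfur needs the methyl of the thiadiazole, which an unsubstituted 1,3,4-thiadiazol-2-yl or a pyridin-2-yl on the same sulfur would test. Also open, on these data alone, is how the change behaves with a methoxy group or fluorine in place of the chloro or methyl on the aromatic carbon.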